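Chloro to fluoro swap on the shared core

The source may report more compounds than this note shows. Statements on the series, on what has been measured and on what is new or still open speak of the compounds shown alone.

Measured so far in a functional assay on MDA-MB-231 cells (Homo sapiens) for cytotoxicity, read by sulforhodamine B assay, with a stated time of 48 h, in the presence of a further agent that is not named here; on this read-out higher numbers stand for weaker inhibition of growth and lower numbers for stronger inhibition of growth:
compound 1 `CCCCNc1ccnc2cc(F)ccc12` gives 5630 nM
compound 2 `CN(C)CCNc1ccnc2cc(Cl)ccc12` gives 2870 nM

Compound 2 holds the smaller of the two numbers, but the gap to compound 1 lies within the scatter, so the two are not set apart. Compound 3 `CN(C)CCNc1ccnc2cc(F)ccc12` differs from compound 2 by fluoro in place of chloro on an aromatic carbon. Going by the values given here, no measured pair shows this exchange alone, so a step not beyond the scatter is expected, if anything toward a higher number. Compound 3 is estimated at 4000 nM (range 1500 nM to 11000 nM), which means an expected step of a 1.4-fold higher number from compound 2 to compound 3 (0.14 log units; within the scatter).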

Compound 3, concentration for 50% growth inhibition: 1940 nM
Estimate against measurement, compound 3: 2.1-fold (0.31 log units) above; measured number inside the range.
By their numbers in this assay, from the lowest: compounds 3, 2 and 1 (each within the scatter of the next, the first and the last beyond it).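

Within this assay the exchange of fluoro in place of chloro on an aromatic carbon gives a 1.5-fold lower number from compound 2 to compound 3 (0.17 log units; within the scatter) and so does not set these two compounds apart on the shared core. On the side chain, dimethylamino in place of ethyl on a saturated chain carbon gives a 2.9-fold lower number from compound 1 to compound 3 (0.46 log units; beyond the scatter) and this modest step is the only one shown beyond the scatter. Nothing at hand gives a reason for either step.

Still open, as far as these compounds go, is whether bromo or a nitrile on the same aromatic carbon would also stay within the scatter. Also open, from the compounds shown here alone, is whether a longer chain carrying the dimethylamino group, or a piperidine in its place, would keep the step seen on the side chain.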